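Lengthening the nitrile chain on a shared core

A few compounds are considered here, and "the series" means these few. Any claim that something is new, unique, unknown or untested is made for them only; others in the source may bear on it.

Measured compounds and their values in an assay on HEK293 cells for binding affinity to Substance-K receptor (Rattus norvegicus), read by FRET, tested at 10 uM; a lower number here means less inhibition, a higher number more inhibition at the concentration tested (going by the name of the read-out):
- compound 1 `N#CCN(Cc1ccccc1)Cc1ccc2ccccc2c1` gives 0%
- compound 2 `N#CCN(Cc1ccc(I)cc1)Cc1ccc2ccccc2c1` gives 0%
- compound 3 `N#CCN(Cc1ccc(CCc2ccccc2)cc1)Cc1ccc2ccccc2c1` gives 20%

Going by the values given here, compound 1 sits level with compound 2 at the digits printed, and together they form the lowest pair of the three; the only compound that stands apart is compound 3, reached by a number 20 percentage points higher from compound 1 to compound 3 (beyond the scatter), a modest rise.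

Compound 4 `N#CCCCN(Cc1ccccc1)Cc1ccc2ccccc2c1` differs from compound 1 in one place: 2-cyanoethyl in place of cyano on a saturated chain carbon bound to an amine nitrogen. Every measured step here concerns a substituent on an aromatic carbon, whether no change at the digits printed from compound 1 to compound 2 (within the scatter) or a number 20 percentage points higher from compound 2 to compound 3 (beyond the scatter), and none touches the chain on the saturated carbon bound to the amine nitrogen. Among the compounds with values here, there is therefore no measured step that bears directly on this change, and no basis for predicting a rise. The expectation is that compound 4 stays near compound 1, with a step of a number 5 percentage points higher from compound 1 to compound 4 (within the scatter) expected. Compound 4 is estimated at 5%, with a range from 0% to 25%.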

Compound 4, a percentage reported as inhibition, at one concentration (the size of the read-out at that concentration, not a potency): 0%
The estimate for compound 4 lay 5 percentage points above the measured number, within the range that was stated.
By their numbers in this assay, from the lowest: compounds 1, 2 and 4 (each within the scatter of the next); then compound 3.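

This is the first change shown on the saturated chain carbon bound to an amine nitrogen, where cyanomethyl becomes 3-cyanopropyl, and in this assay it gives no change at the digits printed from compound 1 to compound 4 (within the scatter). On the core of compound 1, then, lengthening the chain while keeping the nitrile at its end does not produce a rise like the one phenethyl gives on the aromatic carbon, a number 20 percentage points higher from compound 1 to compound 3 (beyond the scatter). Nothing available explains why the number stays where it does.

As far as these compounds go, it remains open whether the same chain change would matter on compound 3, which already gives a measurable reading. Also open, from the compounds shown here alone, is whether a carboxylic acid or an amine in place of the nitrile, or a still longer chain, would move the number.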